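Swapping Anilino for 3-Fluorophenyl on the Carbonyl Carbon

A few compounds are considered here, and "the series" means these few. Any claim that something is new, unique, unknown or untested is made for them only; others in the source may bear on it.

Of the compounds shown here, two built on one shared core have been tested in an ADME assay on HepG2 cells (Homo sapiens) for cytotoxicity; a lower number here means that less compound is needed, a higher number that more compound is needed for the effect. Compound 1 `Cc1ccc(S(=O)(=O)N[C@@H](CC(=O)NC(C)(C)C)C(=O)NCCNC(=O)c2cc(Cl)ccn2)cc1` carries a 4-chloropyridin-2-yl group on a carbonyl carbon. In this assay compound 1 gives > 11000 nM, which is a limit of the assay rather than a measured number. Compound 2 `Cc1ccc(S(=O)(=O)N[C@@H](CC(=O)NC(C)(C)C)C(=O)NCCNC(=O)Nc2ccccc2)cc1` carries an anilino group at that carbonyl carbon instead. In this assay compound 2 gives > 11000 nM, again a limit and not a number. The step that the two limits leave unreadable from compound 1 to compound 2 therefore cannot be read in size or direction. Where compound 2 stands is known only as a limit, a position it shares with compound 1, as the limit of > 11000 nM in this assay, at which 2 of the 2 values shown sit, shows.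

Compound 3 `Cc1ccc(S(=O)(=O)N[C@@H](CC(=O)NC(C)(C)C)C(=O)NCCNC(=O)c2cccc(F)c2)cc1` has not yet been tested. Its difference from compound 2 is 3-fluorophenyl in place of anilino on a carbonyl carbon. No readable measured step bears on this change. The expectation is that compound 3 will again sit at the limit, with no step beyond the scatter, so the estimated step is a step that the limit leaves unreadable from compound 2 to compound 3. For compound 3 the estimate in this assay is 15000 nM, expected to lie between 7000 nM and 40000 nM.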

Compound 3, half-maximal effective concentration: > 11000 nM
Compound 3 gave a limit, no number (the forecaster's own chance of this, stated with the estimate: 80%); the middle value does not contradict the limit.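

In this assay compound 3 gives > 11000 nM, again a limit of the assay and not a number, so no step among compound 1, compound 2 and compound 3 can be read: the limit of > 11000 nM in this assay, at which 3 of the 3 values shown sit.

The compounds shown leave open how much of each is actually needed for the effect, and whether any group on this carbonyl carbon would give a readable number.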